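This account rests on a few compounds, and the source may have more. Where it says the series, first, only, none or still open, it means among the compounds named here.

Compound 1 `Cc1cc(C)cc(SCc2ccc(/C=C/C(=O)Nc3ccccc3N)cc2)c1`: 11.7%
Compound 2 `Nc1ccccc1NC(=O)/C=C/c1ccc(CSc2cccc(F)c2)cc1`: 2.25%

In a functional assay on HeLa cells (Homo sapiens) for inhibition, read by CCK-8 assay, with a stated time of 72 h, tested at 2 uM (a higher number here means more inhibition of growth at the concentration tested, a lower number less inhibition of growth), compound 2 gives 2.25%. Among the compounds with values here, the only other number so far comes from compound 1, at 11.7%, and the two lie within the scatter of each other, so they cannot be told apart.

Compound 3 `CCc1ccc(SCc2ccc(/C=C/C(=O)Nc3ccccc3N)cc2)cc1` has not yet been measured. It differs from compound 2 in one place, with 4-ethylphenyl in place of 3-fluorophenyl on a sulfur.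

Within the data shown here, one measured step bears on this, a swap of the group on that same sulfur: a number 9.5 percentage points lower from compound 1 to compound 2 (within the scatter). Among the measured compounds shown here, no measured compound carries 4-ethylphenyl, so the data point in no clear direction. The step expected in this assay is a number 4.8 percentage points higher from compound 2 to compound 3 (within the scatter), which means none beyond the scatter. For compound 3 the estimate is 7%, with an expected range of 0% to 18%.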

Compound 3, percent growth inhibition at one concentration: 3.96%
Compound 3: middle estimate off by 3 percentage points, on the high side; the range from low to high includes it.
By their numbers in this assay, from the lowest: compounds 2, 3 and 1 (each within the scatter of the next).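

In this assay, the new group gives a number 1.7 percentage points higher from compound 2 to compound 3 (within the scatter) and a number 7.7 percentage points lower from compound 1 to compound 3 (within the scatter), so neither step can be read as a real change. Within the data shown here, the earlier pair offered only one comparison on this sulfur, whereas three different phenyl groups now sit there, 3,5-dimethylphenyl, 3-fluorophenyl and 4-ethylphenyl, and none of them can be told apart from the others at this single concentration. Nothing measured here offers an explanation for these readings.

As far as these compounds go, all three groups on the sulfur are carbon-only six-membered aromatic rings bearing small substituents, so it remains open whether an amine, a carboxylic acid or a saturated ring such as cyclohexyl at this place would move the number beyond the scatter. From the compounds shown here alone, whether these three compounds would separate at other concentrations also stays unknown.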